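The compounds below may be only part of what the source reports. "The series", "measured", "known", "first", "only" and "open" are said of these compounds alone.

Measured compounds:
Compound 1 `CC/C=C/C(=O)Nc1cc2c(N3CCCc4ccccc43)ncnc2cc1OC` gives 6310 nM in a functional assay on PC-3 cells (Homo sapiens) for antiproliferative activity, read by MTT assay, with a stated time of 72 h; on this read-out lower numbers stand for stronger inhibition and higher numbers for weaker inhibition.
Compound 2 `COc1cc2ncnc(N3CCCc4ccccc43)c2cc1NC(=O)/C=C/C(C)C` gives 8430 nM in this assay.
Compound 3 `CCC/C=C/C(=O)Nc1cc2c(N3CCCc4ccccc43)ncnc2cc1OC` gives 2240 nM in this assay.

All three share one core and differ only in the chain of the amide. Compound 3 stands lowest of the three numbers, and both of its steps lie beyond the scatter: a 2.8-fold lower number from compound 1 to compound 3 (0.45 log units; beyond the scatter) and a 3.8-fold lower number from compound 2 to compound 3 (0.58 log units; beyond the scatter). It is therefore the strongest inhibitor of the three. Compound 1 and compound 2 cannot be ordered against each other, since a 1.3-fold higher number from compound 1 to compound 2 (0.13 log units; within the scatter).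

Compound 4 `CCN(CC)C/C=C/C(=O)Nc1cc2c(N3CCCc4ccccc43)ncnc2cc1OC` differs from compound 3 in one place: diethylamino in place of ethyl on a saturated chain carbon bound to a double-bonded chain carbon. Among the compounds with values here, no measured step bears directly on this change; the measured steps only move a methyl along the chain or swap propyl for isopropyl at the chain end, and none of them brings a nitrogen into the chain. The two modest steps into compound 3 show that the shape of the chain end matters, but they give no direction for a diethylamino group. A step of modest size in either direction is therefore the most that can be expected, with none beyond the scatter as the central guess. For compound 4 the estimate in this assay is 2000 nM, with a range from 500 nM to 8000 nM, which is expected to mean a 1.1-fold lower number from compound 3 to compound 4 (0.05 log units; within the scatter).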

Compound 4, half-maximal inhibitory concentration: 6890 nM
Beside the measured number, compound 4's estimate is 3.4-fold (0.54 log units) below it; measured number inside the range.
By their numbers in this assay, from the lowest: compound 3; then compounds 1, 4 and 2 (each within the scatter of the next).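

Within the data shown here, this is the first nitrogen in the chain, and at this saturated chain carbon bound to a double-bonded chain carbon it gives up the edge that compound 3 held in this assay: diethylamino in place of ethyl brings a modest step in the weaker direction (a 3.1-fold higher number from compound 3 to compound 4 (0.49 log units; beyond the scatter)). Set against the ethyl-ended chain (a 1.1-fold higher number from compound 1 to compound 4 (0.04 log units; within the scatter)) and the isopropyl-ended chain (a 1.2-fold lower number from compound 2 to compound 4 (0.09 log units; within the scatter)), the (diethylamino)methyl chain cannot be told apart, so among these four compounds only compound 3, with its propyl end, stands clear of the others. No measurement is at hand that would explain this result.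

The compounds shown cannot separate the effect of the nitrogen from that of the larger group, as diethylamino brings in both at once, with 5 heavy atoms in place of 2. As far as these compounds go, whether a smaller amine such as dimethylamino, a ring amine such as piperidine, or a longer carbon chain such as butyl at this place would match compound 3 or fall back with the others remains open.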